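This account rests on a few compounds, and the source may have more. Where it says the series, first, only, none or still open, it means among the compounds named here.

Measured so far in a functional assay on RPMI-8226 cells (Homo sapiens) for cytotoxicity, read by MTT assay, with a stated time of 48 h; a higher number here means a weaker inhibitor, a lower number a stronger inhibitor
Compound 1 `ClC1=C(Cl)C(Cl)=C(Cl)C1=NNc1cc(Cl)cc(Cl)c1` gives 800 nM
Compound 2 `Cc1cccc(NN=C2C(Cl)=C(Cl)C(Cl)=C2Cl)c1` gives 2000 nM

Compound 2 (2000 nM) holds the higher of the two numbers, so it is the weaker inhibitor. Compound 1 (800 nM) lies lower, and the gap between them is beyond the scatter.

Compound 3 `ClC1=C(Cl)C(Cl)=C(Cl)C1=NNc1ccccc1` follows from compound 2 by hydrogen in place of methyl on an aromatic carbon. Among the measured compounds shown here, no pair of measured compounds differs in one place only, so this change has no direct precedent. Compound 2 at 2000 nM is therefore the anchor for the expectation. The estimated step (a 1.3-fold higher number from compound 2 to compound 3 (0.10 log units; within the scatter)) is expected to stay within the scatter, with at most a slight lean towards a higher number. Compound 3 is expected at an estimated 2500 nM, within a range from 900 nM to 6000 nM.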

Compound 3, half-maximal inhibitory concentration: 600 nM
For compound 3 the middle estimate is 4.2-fold (0.62 log units) above the measured one, and the stated range ends above it.
By their numbers in this assay, from the lowest: compounds 3 and 1 (each within the scatter of the next); then compound 2.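

In this assay, replacing the methyl on an aromatic carbon, meta to a large group, with hydrogen gives a 3.3-fold lower number from compound 2 to compound 3 (0.52 log units; beyond the scatter). Among the compounds shown here, this is the first change in a single place that can be read here, and it shows that this position is not indifferent to a group as small as methyl: compound 3, with hydrogen there, is the stronger inhibitor of this pair. No measurement among the data shown accounts for this step.

The compounds shown leave open whether other groups at this position, such as an ethyl, a methoxy, an amine or a carboxylic acid, would also raise the number relative to hydrogen. They also leave open how far a single methyl at another carbon of this ring would move the number.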